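Amide-nitrogen substituent variation on the quinolinone series

A few compounds are considered here, and "the series" means these few. Any claim that something is new, unique, unknown or untested is made for them only; others in the source may bear on it.

Measured compounds:
compound 1 `C#CCn1cc(C(=O)NC(CC(=O)Nc2ccccn2)c2ccccc2)c(=O)c2ccc(Cl)nc21` — 5200 nM
compound 2 `C#CCn1cc(C(=O)NC(CC(=O)Nc2ccccc2)c2ccccc2)c(=O)c2ccc(Cl)nc21` — > 10000 nM

In a functional assay on KB cells (Homo sapiens) for cytotoxicity, read by MTT assay, with a stated time of 72 h (on this read-out higher numbers stand for weaker inhibition and lower numbers for stronger inhibition), compound 1 gives 5200 nM. In this assay compound 2 gives > 10000 nM, which is a limit of the assay and not a number; compound 2 sits at the limit of > 10000 nM in this assay, at which 1 of the 2 values shown sits. Going by the values given here, the single measured step, an at least 1.9-fold higher number from compound 1 to compound 2 (0.28 log units; that floor lies within the scatter), therefore reads as a floor only.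

Compound 3 `C#CCn1cc(C(=O)NC(CC(=O)NC2CCCC2)c2ccccc2)c(=O)c2ccc(Cl)nc21` differs from compound 2 by cyclopentyl in place of phenyl on an amide-type nitrogen. Among the compounds with values here, no measured step covers a change from an aromatic to a non-aromatic group at this amide-type nitrogen; the one measured step concerns pyridin-2-yl against phenyl at the same place and is itself bounded by the limit. There is thus no basis for expecting compound 3 to move off the limit in either direction, and the expected step that the limit leaves unreadable from compound 2 to compound 3 is essentially none beyond the scatter. Compound 3 is estimated in this assay at 12000 nM, with a range from 4000 nM to 40000 nM, and with a considerable chance that only a limit is again reported.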

Compound 3, half-maximal inhibitory concentration: > 10000 nM
Compound 3 gave a limit, no number (the forecaster's own chance of this, stated with the estimate: 60%); the middle value is on the limit's open side.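

With cyclopentyl on the amide-type nitrogen, a non-aromatic ring of carbon only stands at this place, and in this assay compound 3 gives > 10000 nM, which is a limit of the assay and not a number. Set against pyridin-2-yl, the cyclopentyl change reads as an at least 1.9-fold higher number from compound 1 to compound 3 (0.28 log units; that floor lies within the scatter), so this comparison is a floor only, as it was for phenyl. The step between phenyl and cyclopentyl cannot be read, and the aromatic and the non-aromatic carbon ring are not separated on this read-out, with pyridin-2-yl alone still giving a number: the limit of > 10000 nM in this assay, at which 2 of the 3 values shown sit.

Going by these compounds, whether pyridin-2-yl truly differs from either carbon-only ring stays open, as both floors lie within the scatter and the true values of compound 2 and compound 3 are unknown. Also open, on these data alone, is how a morpholin-4-yl ring, a pyridin-4-yl ring or a 2-aminoethyl chain on this amide-type nitrogen would read in this assay, and whether any such group would give a number clearly lower than that of compound 1.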